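The source may hold more compounds than are shown below. What is called first, only, known or untested is meant among the compounds shown, and "the series" means these compounds.

In an assay on cell membranes from brain for binding affinity to Adrenergic receptor alpha-1 (Rattus norvegicus), read by radioligand binding (on this read-out higher numbers stand for weaker inhibition and lower numbers for stronger inhibition), compound 1 `O=c1ccc(-n2cnc3ccccc32)nn1CCN1CCN(c2ccccc2Cl)CC1` gives 70.4 nM, while compound 2 `O=c1ccc(-n2cnc3ccccc32)nn1CCCCN1CCN(c2ccccc2Cl)CC1` gives 1.3 nM, the lower of the two numbers, a gap that lies beyond the usual scatter. Compound 3 `O=c1ccc(-n2ccnc2)nn1CCCCN1CCN(c2ccccc2Cl)CC1` is not yet measured in this assay. It differs from compound 2 by 1H-imidazol-1-yl in place of 1H-benzimidazol-1-yl on an aromatic carbon. Among the compounds with values here, no step between measured compounds covers this change, so the expectation rests on compound 2 alone: a modest rise in the number is expected, estimated at a 3.8-fold higher number from compound 2 to compound 3 (0.59 log units; beyond the scatter). For compound 3 in this assay the estimate is 5 nM, within a range from 1.5 nM to 20 nM.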

Compound 3, inhibition constant: 24.6 nM
Beside the measured number, compound 3's estimate is 4.9-fold (0.69 log units) below it, outside the stated range (above it).
By their numbers in this assay, from the lowest: compound 2; then compound 3; then compound 1.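

In this assay, removing the six-membered aromatic ring of carbon only from 1H-benzimidazol-1-yl, which leaves 1H-imidazol-1-yl on the same aromatic carbon, gives a 19-fold higher number from compound 2 to compound 3 (1.28 log units; beyond the scatter), a large step. The number at this position therefore depends strongly on the group carried there, even though the hydrogen-bond donor and acceptor counts of the two groups are equal. Nothing shown explains the size of this step. The compounds leave open whether a phenyl or pyridine group here would keep the low number of compound 2. They also leave open whether the same exchange would have a similar effect on the chain of compound 1.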